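The source may hold more compounds than are shown below. What is called first, only, known or untested is meant among the compounds shown, and "the series" means these compounds.

Compound 1 `COc1ccc(-c2nc(SCC(=O)c3sc(-c4ccccc4)nc3C)nc(N)c2C#N)cc1` gives the lowest number of the three measured compounds in a functional assay on U-87MG ATCC cells for antiproliferative activity against U-87 MG (Homo sapiens), read by MTT assay, with a stated time of 48 h, tested at 10 uM (on this read-out lower numbers stand for a stronger effect and higher numbers for a weaker effect at the one concentration tested), at 60.8%. Compound 3 `Cc1nc(-c2ccccc2)sc1C(=O)CSc1nc(-c2cccc(Cl)c2)c(C#N)c(=O)[nH]1` stands higher in this assay at 83.7%, and compound 2 `Cc1nc(-c2ccc(Cl)cc2)sc1C(=O)CSc1nc(-c2ccc(Cl)c(Cl)c2)c(C#N)c(=O)[nH]1` higher still at 97.1%; both gaps from compound 1 lie beyond the scatter. Compound 4 `Cc1nc(-c2ccccc2)sc1C(=O)CSc1nc(N)c(C#N)c(-c2ccccc2)n1` has not yet been measured. It differs from compound 1 by hydrogen in place of methoxy on an aromatic carbon. Among the compounds with values here, no measured pair shows this change alone, so the direction of the step is open; the expectation is a modest move toward a weaker effect, of a size that may not exceed the scatter, giving an estimated step of a number 7.2 percentage points higher from compound 1 to compound 4 (within the scatter). On that basis compound 4 is expected to give about 68% in this assay, within a range from 50% to 88%.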

Compound 4, a percentage reported as activity, at one concentration (the size of the read-out at that concentration, not a potency): 93%
For compound 4 the middle estimate is 25 percentage points below the measured one; the measured number lies above the stated range.
By their numbers in this assay, from the lowest: compound 1; then compounds 3, 4 and 2 (each within the scatter of the next, the first and the last beyond it).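

Within the data shown here, replacing methoxy with hydrogen on the aromatic carbon para to a large group is the first single change that can be read in this assay, and it gives a number 32.2 percentage points higher from compound 1 to compound 4 (beyond the scatter). This pair thus shows that the effect seen with compound 1 at this one concentration depends on the 4-methoxyphenyl group, with phenyl not serving in its place. Nothing available explains the size of this step. From the compounds shown here alone, whether a hydroxyl, an ethoxy group or a fluorine at this position would behave like methoxy remains open. A single pair also cannot show whether the step would hold on another core.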